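This account rests on a few compounds, and the source may have more. Where it says the series, first, only, none or still open, it means among the compounds named here.

Measured compounds
Compound 1 `CCN(c1ccc(C#N)c(Cl)c1)c1cc(-c2ccccc2)ccc1C` — "not determined" (no result reported)
Compound 2 `CCN(c1cccc(-c2ccccc2)c1)c1ccc(C#N)c(Cl)c1` — "not determined" (no result reported)
Compound 3 `CCN(c1ccc(C#N)c(C(F)(F)F)c1)c1cc(-n2ccnc2)ccc1C` — > 30000 nM

The series is examined in a functional assay on PC-3 cells (Homo sapiens) for antiproliferative activity, read by CCK-8 assay, with a stated time of 6 days; on this read-out higher numbers stand for weaker inhibition and lower numbers for stronger inhibition. Compound 1 stands without a single number: for compound 1 the read-out is "not determined" (no result reported). Compound 2 likewise shows "not determined" (no result reported). Compound 3 is the only entry with a read-out, and that read-out is a limit of the assay rather than a number: compound 3 gives > 30000 nM. Thus the only firm point is the limit of > 30000 nM in this assay, at which 1 of the 3 values shown sits.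

The step of interest leads from compound 1 to compound 4 `CCN(c1ccc(C#N)c(Cl)c1)c1cc(-c2cn[nH]c2)ccc1C`, and the change is 1H-pyrazol-4-yl in place of phenyl on an aromatic carbon. Within the data shown here, no measured step between two compounds exists here, so the size of the step in this assay cannot be drawn from a neighbouring pair; with compound 3 reaching only a limit, no direction beyond the scatter is claimed.

Compound 4 is estimated at 20000 nM, with an expected range from 3000 nM to 30000 nM, and a limit is expected to be a likely outcome as well.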

Compound 4, half-maximal inhibitory concentration: 15300 nM
Estimate against measurement, compound 4: 1.3-fold (0.12 log units) above; the range from low to high includes it.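

In this assay, among these compounds, compound 4 gives 15300 nM but compound 1 shows "not determined" (no result reported) and so no step between these two compounds can be read. The compounds shown leave open whether 1H-pyrazol-4-yl in place of phenyl changes the read-out at all, and in which direction.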